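The source may report more compounds than this note shows. Statements on the series, on what has been measured and on what is new or still open speak of the compounds shown alone.

Compound 1 `CC(C)n1ncc2c(C(=O)NCCN(C)C)cc(C(C)(C)C)nc21`: 34400 nM
Compound 2 `CC(C)n1ncc2c(C(=O)NCCN)cc(C(C)(C)C)nc21`: 23000 nM

Both numbers come from an ADME assay on Vero cells (Chlorocebus sabaeus) for cytotoxicity, read by neutral red uptake, with a stated time of 3 days; a lower number here means that less compound is tolerated, a higher number that more compound is tolerated. Within the data shown here, the single step connecting them, a 1.5-fold lower number from compound 1 to compound 2 (0.17 log units; within the scatter), lies within the scatter. Compound 2 stands at the lower of the two numbers, but since the gap to compound 1 is within the scatter, no order between the two compounds is claimed.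

Compound 3 `Cc1cc(C(=O)NCCN)c2cnn(C(C)C)c2n1` has not yet been measured in this assay. From compound 2 it differs in one place: methyl in place of tert-butyl on an aromatic carbon. Among the measured compounds shown here, no measured step concerns this aromatic carbon; the only measured step concerns the chain end and gives no direct guidance, beyond showing that one small change left this assay within the scatter. The expectation is therefore no step beyond the scatter, a 1.1-fold higher number from compound 2 to compound 3 (0.04 log units; within the scatter). Compound 3 is estimated at 25000 nM, with a range from 12000 nM to 55000 nM.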

Compound 3, half-maximal cytotoxic concentration: > 300000 nM
Compound 3 was reported as a limit (the forecaster's own chance of this, stated with the estimate: 10%); middle value at least 12-fold (1.07 log units) away from the limit.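

In this assay, methyl in place of tert-butyl on the aromatic carbon next to the ring nitrogen gives an at least 13-fold higher number from compound 2 to compound 3 (1.11 log units; beyond the scatter), whereas the change at the chain end gave a 1.5-fold lower number from compound 1 to compound 2 (0.17 log units; within the scatter). This aromatic carbon is therefore the first place in the series where a single change moves the number beyond the scatter, and with methyl there more compound is tolerated; this rests on one pair only. From the compounds shown here alone, the reading for compound 3 is a limit and not a number, so the full size of the step stays unknown: the limit of > 300000 nM in this assay, at which 1 of the 3 values shown sits.

The compounds shown leave open whether hydrogen, ethyl or isopropyl on this carbon would sit nearer compound 2 or compound 3. Also open, going by these compounds, is whether the step keeps its size with the dimethylamino chain end of compound 1.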